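The compounds below may be only part of what the source reports. "The series", "measured", "known", "first", "only" and "open" are said of these compounds alone.

Measured compounds:
Compound 1, `c1ccc(-c2[nH]c3ccccc3c2C2CC(c3ccncc3)=NO2)cc1`: 70.5 ug/mL
Compound 2, `c1ccc(-c2[nH]c3ccccc3c2C2CC(c3ccncc3)=NN2)cc1`: 21 ug/mL

In a functional assay, read by Griess assay, in phosphate buffer, with a stated time of 90 min, in the presence of a further agent that is not named here (on this read-out lower numbers stand for stronger inhibition and higher numbers for weaker inhibition), compound 1 gives 70.5 ug/mL, the highest of the two numbers at hand. Compound 2 gives 21 ug/mL in this assay, a lower number, and the gap between the two lies beyond the usual scatter of repeated measurements. Going by the values given here, no pair of measured compounds differs in a single place, so no measured step is available.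

Compound 3, `c1ccc(-c2[nH]c3ccccc3c2C2CC(c3cccnc3)=NO2)cc1`, has not yet been measured in this assay. It differs from compound 1 in one place: pyridin-3-yl in place of pyridin-4-yl on a carbon with a double bond to nitrogen. Among the compounds with values here, nothing among the measured compounds shows how such a change acts in this assay. The step is therefore expected to be small, a 1.2-fold lower number from compound 1 to compound 3 (0.07 log units; within the scatter), with no change beyond the scatter in either direction. Compound 3 is accordingly estimated at 60 ug/mL in this assay, with a range from 28 ug/mL to 130 ug/mL.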

Compound 3, half-maximal inhibitory concentration: 117 ug/mL
The estimate for compound 3 lay 2.0-fold (0.29 log units) below the measured number; the measured number falls inside the stated range.
By their numbers in this assay, from the lowest: compound 2; then compounds 1 and 3 (each within the scatter of the next).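

In this assay the position on the carbon with a double bond to nitrogen now has its first measured step: pyridin-3-yl in place of pyridin-4-yl gives a 1.7-fold higher number from compound 1 to compound 3 (0.22 log units; within the scatter) and so stays within the scatter. The earlier compounds shown here could not show this, and on this read-out the change of the pyridine attachment alone does not separate the two compounds. No measurement at hand accounts for this result.

On these data alone, whether pyridin-2-yl, or a ring carrying an amine or a carboxylic acid, would move the number beyond the scatter at this position remains open. As far as these compounds go, it is also open whether the same change from pyridin-4-yl to pyridin-3-yl would give a similar step on the core of compound 2.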